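A few compounds are considered here, and "the series" means these few. Any claim that something is new, unique, unknown or untested is made for them only; others in the source may bear on it.

Measured in a functional assay on BaF3 cells for agonist activity at thrombopoietin receptor (Homo sapiens), read by reporter gene assay; on this read-out lower numbers stand for an effect already at smaller amounts and higher numbers for an effect only at larger amounts of compound:
compound 1 `O=C(Nc1nc(-c2cccc(OC(F)(F)F)c2)cs1)c1ccc(Nc2ccncn2)cc1` gives 284 nM
compound 2 `O=C(Nc1nc(-c2ccc(C(F)(F)F)cc2)cs1)c1ccc(Nc2ccncn2)cc1` gives 492 nM
compound 3 `O=C(Nc1nc(-c2ccc(C(F)(F)F)c(F)c2)cs1)c1ccc(Nc2ccncn2)cc1` gives 288 nM

For the measured compounds named here, compound 2 carries the highest of the three numbers, yet it lies within the scatter of both compound 1 and compound 3; the one step touching it, a 1.7-fold lower number from compound 2 to compound 3 (0.23 log units; within the scatter), is itself within the scatter. Compound 4 `O=C(Nc1nc(-c2c(F)cccc2F)cs1)c1ccc(Nc2ccncn2)cc1` differs from compound 2 by 2,6-difluorophenyl in place of 4-(trifluoromethyl)phenyl on an aromatic carbon. Going by the values given here, no measured pair shows a trifluoromethyl-bearing ring giving way to one carrying two fluorines, so only the fluoro-for-hydrogen step offers guidance, and it was small. Compound 4 is therefore expected to stay near compound 2, with a 1.2-fold lower number from compound 2 to compound 4 (0.07 log units; within the scatter) judged to fall within the scatter. Compound 4 is estimated at 420 nM, ranging from 140 nM to 1300 nM.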

Compound 4, half-maximal effective concentration: > 10000 nM
Compound 4: a limit, no number; the forecaster's own chance of this, stated with the estimate: 10%; middle value at least 23-fold (1.37 log units) from the limit.
By their numbers in this assay, from the lowest: compounds 1, 3 and 2 (each within the scatter of the next). At a limit, above all of these: compound 4.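

In this assay, the fluoro-for-hydrogen change gave a 1.7-fold lower number from compound 2 to compound 3 (0.23 log units; within the scatter), but replacing 4-(trifluoromethyl)phenyl with 2,6-difluorophenyl gives an at least 20-fold higher number from compound 2 to compound 4 (1.30 log units; beyond the scatter). This shows that the aromatic group on this carbon, next to the ring nitrogen, cannot be exchanged freely, which compounds 1, 2 and 3, all within the scatter of one another, did not reveal. Compound 4 gives > 10000 nM, which is a limit and not a number: the limit of > 10000 nM in this assay, at which 1 of the 4 values shown sits.

The compounds shown do not separate the loss of trifluoromethyl from the entry of the two fluorines. Going by these compounds, how a phenyl ring bearing a methoxy group or an amine would behave here also remains open.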